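A step from compound 1 to compound 4

The source may hold more compounds than are shown below. What is called first, only, known or untested is meant among the compounds shown, and "the series" means these compounds.

Measured in a functional assay on CEM13 cells (Homo sapiens) for cytotoxicity, read by MTT assay, with a stated time of 72 h; on this read-out lower numbers stand for stronger inhibition and higher numbers for weaker inhibition:
Compound 1 `Cc1c(C)c2c(c(C)c1OC(=O)CCC(=O)O)CCC(C)(C(=O)NC1CC(C)(C)N([O])C(C)(C)C1)O2`: > 300000 nM, a limit
Compound 2 `Cc1c(C)c2c(c(C)c1O)CCC(C)(C(=O)NC1CC(C)(C)N([O])C(C)(C)C1)O2`: > 300000 nM, a limit
Compound 3 `Cc1c(C)c2c(c(C)c1OC(=O)CCC(=O)NC1CC(C)(C)N([O])C1(C)C)CC[C@@](C)(CCC[C@H](C)CCC[C@H](C)CCCC(C)C)O2`: > 300000 nM, a limit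

In this assay, compound 1 stands at > 300000 nM, which is a limit and not a number. The measured evidence is the limit of > 300000 nM in this assay, at which 3 of the 3 values shown sit. Compound 4 `Cc1c(C)c2c(c(C)c1OC(=O)CCC(=O)O)CCC(C)(C(=O)O)O2` differs from compound 1 by one oxygen atom in place of a group of 12 heavy atoms (9 carbon, 2 nitrogen, 1 oxygen; one six-membered non-aromatic ring with 1 hetero atom), on a carbonyl carbon. For the measured compounds named here, the only measured step from compound 1 is a step that the two limits leave unreadable from compound 1 to compound 2, and it concerns a different change, so it gives no size to carry over. No step beyond the scatter is therefore expected in this assay, and no direction can be given. The expected step is a number no higher from compound 1 to compound 4 (the limit leaves the size open). The estimate for compound 4 is 300000 nM, with an expected range from 150000 nM to 600000 nM.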

Compound 4, half-maximal inhibitory concentration: 191000 nM
Beside the measured number, compound 4's estimate is 1.6-fold (0.20 log units) above it; the measured number falls inside the stated range.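

In this assay, compound 4 is the first compound shown to give a number instead of a limit, at 191000 nM. On this carbonyl carbon, hydroxy in place of the group of 12 heavy atoms gives an at least 1.5-fold lower number from compound 1 to compound 4 (0.19 log units; that floor lies within the scatter). This establishes no step beyond the scatter, but it does show that the measured number can be reached without the six-membered non-aromatic ring group.

As far as these compounds go, the full size of the step stays open: the limit of > 300000 nM in this assay, at which 3 of the 4 values shown sit. The compounds shown also do not tell what an amine or a methyl ester on this carbonyl carbon would give.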